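Pyridin-3-yl in place of 3-(dimethylamino)phenyl: an expectation

This account rests on a few compounds, and the source may have more. Where it says the series, first, only, none or still open, it means among the compounds named here.

Compound 1 `Nc1cccc(C2=NC(c3ccc(F)cc3)(c3ccc(F)cc3)CN2)c1`: 300 nM in an assay on LM cells for displacement of a labelled ligand from Neuropeptide Y receptor type 5 (Homo sapiens); on this read-out higher numbers stand for weaker inhibition and lower numbers for stronger inhibition
Compound 2 `CN(C)c1cccc(C2=NC(c3ccc(F)cc3)(c3ccc(F)cc3)CN2)c1`: > 1000 nM in this assay

Compound 2 stands only at a limit of this assay and has no number of its own (the limit of > 1000 nM in this assay, at which 1 of the 2 values shown sits). Compound 3 `Fc1ccc(C2(c3ccc(F)cc3)CNC(c3cccnc3)=N2)cc1` carries the change (pyridin-3-yl in place of 3-(dimethylamino)phenyl on a carbon with a double bond to nitrogen). Among the compounds with values here, no measured step covers this exchange directly; the only step known, an at least 3.3-fold higher number from compound 1 to compound 2 (0.52 log units; beyond the scatter), concerns the dimethylamino group that now leaves, and it was at least modest in the weakening direction. With that group removed, compound 3 is expected to come in near 800 nM, estimated between 200 nM and 3000 nM. The expected step is therefore an at least 1.2-fold lower number from compound 2 to compound 3 (0.09 log units; that floor lies within the scatter), with a real chance that only a limit is again reported.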

Compound 3, half-maximal inhibitory concentration: 7.2 nM
Compound 3: the middle estimate sits 110-fold (2.05 log units) above what was measured; measured number below the stated range.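

On the carbon between two ring nitrogen atoms, the choice of aromatic group matters far more than the amino-to-dimethylamino step alone could show. Compound 2 has only a limit, not a number: the limit of > 1000 nM in this assay, at which 1 of the 3 values shown sits. Pyridin-3-yl brings an at least 130-fold lower number from compound 2 to compound 3 (2.14 log units; beyond the scatter), and against 3-aminophenyl it brings a 42-fold lower number from compound 1 to compound 3 (1.62 log units; beyond the scatter), so neither substituted phenyl comes near it.

Going by these compounds, each exchange changes the ring and removes the substituent together, so their separate shares remain open. Unsubstituted phenyl would separate them, and pyridin-4-yl would test where the ring nitrogen can sit.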